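Swapping halogens on the pyridine of a sulfonamide series

The source may hold more compounds than are shown below. What is called first, only, known or untested is meant among the compounds shown, and "the series" means these compounds.

Compound 3 `O=S(=O)(CSc1nnc(Br)n1Cc1ccc(Br)c2ccccc12)Nc1cccnc1Br` gives 280 nM in an assay on HEK293 cells for inhibition of solute carrier family 22 member 12 (Homo sapiens) (on this read-out lower numbers stand for stronger inhibition and higher numbers for weaker inhibition), the lowest of the three numbers. Compound 2 `O=S(=O)(CSc1nnc(Br)n1Cc1ccc(Br)c2ccccc12)Nc1ccccc1` gives 15800 nM and compound 1 `NS(=O)(=O)CSc1nnc(Br)n1Cc1ccc(Br)c2ccccc12` gives 365000 nM; the steps of a 23-fold lower number from compound 1 to compound 2 (1.36 log units; beyond the scatter), a 56-fold lower number from compound 2 to compound 3 (1.75 log units; beyond the scatter) and a 1300-fold lower number from compound 1 to compound 3 (3.12 log units; beyond the scatter) are all large. Compound 4 `O=S(=O)(CSc1nnc(Br)n1Cc1ccc(Br)c2ccccc12)Nc1ccc(Cl)nc1Cl` differs from compound 3 by 2,6-dichloropyridin-3-yl in place of 2-bromopyridin-3-yl on a sulfonamide nitrogen. Within the data shown here, none of the measured steps exchanges one substituted pyridine for another; each replaces a whole group on the sulfonamide nitrogen, so they bear only loosely on this change. In this assay a step of a 1.1-fold higher number from compound 3 to compound 4 (0.03 log units; within the scatter) is therefore expected, with no direction claimed beyond the scatter. Compound 4 is estimated at 300 nM, within 80 nM to 1200 nM.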

Compound 4, half-maximal inhibitory concentration: 1660 nM
Beside the measured number, compound 4's estimate is 5.5-fold (0.74 log units) below it, and the stated range ends below it.
By their numbers in this assay, from the lowest: compound 3; then compound 4; then compound 2; then compound 1.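

In this assay, the two substituted pyridines on the sulfonamide nitrogen are not interchangeable: 2,6-dichloropyridin-3-yl in place of 2-bromopyridin-3-yl gives a 5.9-fold higher number from compound 3 to compound 4 (0.77 log units; beyond the scatter) and so gives up part of the earlier gain. That gain is not lost, with a 9.5-fold lower number from compound 2 to compound 4 (0.98 log units; beyond the scatter) and a 220-fold lower number from compound 1 to compound 4 (2.34 log units; beyond the scatter) still on record for the same group. Nothing given here explains the step. The compounds shown leave open whether the step follows the loss of bromine or the presence of two chlorines. A pyridine carrying a single chlorine, or a methoxy group in place of the halogens, would bear on this.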